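A few compounds are considered here, and "the series" means these few. Any claim that something is new, unique, unknown or untested is made for them only; others in the source may bear on it.

Cytotoxicity in an ADME assay on L6 cells (Rattus norvegicus) for cytotoxicity, read by resazurin assay (on this read-out higher numbers stand for weaker inhibition and lower numbers for stronger inhibition), measured so far:

compound 1 `N=C(N)c1ccc2[nH]c(Nc3ccccc3)nc2c1`: 237000 nM
compound 2 `CC(C)CNC(=N)c1ccc(Nc2nc3cc(C(=N)NCC(C)C)ccc3[nH]2)cc1`: 84400 nM
compound 3 `N=C(NC1CCCCC1)c1ccc(Nc2nc3cc(C(=N)NC4CCCCC4)ccc3[nH]2)cc1`: 63700 nM

Compound 1 stands at the highest of the three numbers. Compound 2 gives a lower number, and compound 3 gives the lowest of the set; both gaps from compound 1 lie beyond the scatter. Compounds 2 and 3 carry substituted amidines on both ends of the shared core, whereas compound 1 carries a free amidine and an unsubstituted phenyl, so the two larger compounds are not one-place neighbours of compound 1 and no single-change step can be read from them.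

The next compound to be measured is compound 4 `N=C(N)c1ccc2[nH]c(Nc3ccc(Cl)cc3)nc2c1`. It differs from compound 1 by chloro in place of hydrogen on an aromatic carbon. Among the measured compounds shown here, no measured pair shows this change, so the size of the step is open. A single chloro on the aromatic ring is a small change against the frame of compound 1, and the step in this assay is expected to be small, most likely within the scatter, with any drift toward a lower number.

Compound 4 is therefore expected to give about 180000 nM, within a range of 80000 nM to 400000 nM, the step from compound 1 to compound 4 being estimated at a 1.3-fold lower number from compound 1 to compound 4 (0.12 log units; within the scatter).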

Compound 4, half-maximal inhibitory concentration: 41600 nM
Beside the measured number, compound 4's estimate is 4.3-fold (0.64 log units) above it; measured number below the stated range.
By their numbers in this assay, from the lowest: compounds 4, 3 and 2 (each within the scatter of the next, the first and the last beyond it); then compound 1.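

In this assay, chloro in place of hydrogen on an aromatic carbon is the only one-place change among the compounds shown, and it gives a 5.7-fold lower number from compound 1 to compound 4 (0.76 log units; beyond the scatter). The place, on a six-membered aromatic ring of carbon only and para to a large group, is therefore not silent in this series: a single chlorine atom, with no ring and no hydrogen-bond donors or acceptors added, moves the number beyond the usual scatter. No measurement at hand bears on what lies behind this step.

From the compounds shown here alone, with one change at one place, it remains open whether the step belongs to chloro in particular or would also appear with fluoro, bromo, methyl, methoxy or trifluoromethyl at the same place, and whether chloro elsewhere on that ring would give a step of similar size. Going by these compounds, it also remains open whether chloro at this place would give a comparable step on a frame bearing substituted amidines, such as those of compound 2 and compound 3, since neither has a one-place chloro partner here.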